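Removing a Silicon-Bearing Group from Compound 3

The compounds below may be only part of what the source reports. "The series", "measured", "known", "first", "only" and "open" are said of these compounds alone.

compound 1 `O=C1CC(CCc2ccccc2)SS1`: 258000 nM
compound 2 `Cc1cn([C@H]2C[C@H](O[Si](C)(C)C(C)(C)C)[C@@H](C3CC(=O)SS3)O2)c(=O)[nH]c1=O`: "not determined" (no result reported)
compound 3 `Cc1cn([C@H]2C[C@H](O[Si](C)(C)C(C)(C)C)[C@@H](C3CC(=O)S[S+]3[O-])O2)c(=O)[nH]c1=O`: 43100 nM

Among the compounds with values here, these compounds were examined in a functional assay on HeLa cells (Homo sapiens) for cytotoxicity, read by MTT assay (a higher number here means a weaker inhibitor, a lower number a stronger inhibitor), and only two gave a number. Compound 3 has the lower of those two numbers, which makes it the stronger inhibitor. Compound 1 lies higher, beyond the scatter, while compound 2 has no result to compare.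

Compound 4 `Cc1cn([C@H]2C[C@H](O)[C@@H](C3CC(=O)S[S+]3[O-])O2)c(=O)[nH]c1=O` has not yet been measured. It differs from compound 3 in one place, on an oxygen on a saturated carbon (a hydrogen atom in place of a group of 7 heavy atoms (6 carbon, 1 silicon; no ring), on an oxygen on a saturated carbon). Within the data shown here, no measured pair shows this change on its own, so any expectation is a judgement. Starting from compound 3 (43100 nM), losing so large a group is expected to raise the number in this assay by a moderate step beyond the scatter, towards weaker inhibition. The estimated change is a 3.0-fold higher number from compound 3 to compound 4 (0.48 log units; beyond the scatter) on this reading. For compound 4 the expected value is 130000 nM within an estimated range of 45000 nM to 400000 nM in this test.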

Compound 4, half-maximal inhibitory concentration: 119000 nM
Compound 4: the middle estimate sits 1.1-fold (0.04 log units) above what was measured; measured number inside the range.
By their numbers in this assay, from the lowest: compound 3; then compound 4; then compound 1.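

In this assay the swap of the group of 7 heavy atoms (6 carbon, 1 silicon) for a hydrogen atom, on an oxygen on a saturated carbon, gives a 2.8-fold higher number from compound 3 to compound 4 (0.44 log units; beyond the scatter) and so moves towards weaker inhibition. Within the data shown here, this is the first measured pair to isolate a change at this position, and it shows that the group counts for something here, though the size of the step is modest and compound 4 still gives a number. No supporting measurement accounts for the step, so it stands as an observation without an explanation.

Going by these compounds, whether a smaller group on that oxygen, such as a methyl ether or an acetyl ester, would give a number closer to compound 3 or to compound 4 remains open. So does the outcome of replacing that oxygen with an amine.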